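A Methyl Becomes Ethyl on a Core That Shows No Activity

A few compounds are considered here, and "the series" means these few. Any claim that something is new, unique, unknown or untested is made for them only; others in the source may bear on it.

Measured compounds:
compound 1 `Cc1nc(NC(C)C)c2cnn(-c3ccccc3)c2n1`: > 100000 nM
compound 2 `Cc1nc(NCc2ccco2)c2cnn(-c3ccccc3)c2n1`: > 100000 nM

In a functional assay on G-361 cells (Homo sapiens) for cytotoxicity, read by sulforhodamine B assay (a higher number here means a weaker inhibitor of growth, a lower number a stronger inhibitor of growth), compound 1 gives > 100000 nM, which is a limit of the assay and not a number. Compound 2 gives > 100000 nM in this assay, also a limit. Within the data shown here, the one measured step, a step that the two limits leave unreadable from compound 1 to compound 2, has no readable size, since (the limit of > 100000 nM in this assay, at which 2 of the 2 values shown sit). Compound 3 `CCc1nc(NC(C)C)c2cnn(-c3ccccc3)c2n1` differs from compound 1 by methyl in place of hydrogen on a saturated chain carbon bound to an aromatic carbon. Among the measured compounds shown here, no measured step bears on this change, and compound 1 itself stands only at a limit. Compound 3 is expected to stay near that limit, a step of a number no higher from compound 1 to compound 3 (the limit leaves the size open). The estimate for compound 3 is 100000 nM, between 30000 nM and 300000 nM.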

Compound 3, concentration for total growth inhibition: > 100000 nM
Compound 3: only a limit was reported; the forecaster's own chance of this, stated with the estimate: 80%; the middle value lies on the limit itself.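

Compound 1 and compound 3 both stand at a limit and not at a number, so no step can be read between them: the limit of > 100000 nM in this assay, at which 3 of the 3 values shown sit. The compounds shown leave open whether methyl in place of hydrogen changes growth inhibition at all.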